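The source may hold more compounds than are shown below. What is called first, only, known or untested is meant among the compounds shown, and "the series" means these compounds.

Measured so far:
Compound 1: `C=CCCC(=O)N1CC(CC=C)C1=O` gives 61800 nM in an assay for inhibition of Fatty-acid amide hydrolase 1 (Homo sapiens); on this read-out higher numbers stand for weaker inhibition and lower numbers for stronger inhibition.
Compound 2: `C=CCCC(=O)N1CC(CCC=C)C1=O` gives 21900 nM in this assay.

Among the measured compounds shown here, compound 2 holds the lower of the two numbers; its only neighbour is compound 1. For the measured compounds named here, the step of a 2.8-fold lower number from compound 1 to compound 2 (0.45 log units; beyond the scatter) is the one measured step so far, and the two compounds differ in one place: allyl in place of vinyl on a saturated chain carbon bound to a saturated ring carbon. Compound 3, `C=CCCCC1CN(C(=O)CCC=C)C1=O`, is not yet measured. It differs from compound 2 in one place: allyl in place of vinyl on a saturated chain carbon, two bonds along the chain from a saturated ring carbon. This is the same kind of lengthening as the step from compound 1 to compound 2, cut one bond further out. Going by the values given here, that earlier step is the only evidence that bears on it. A further lowering of the number in this assay is therefore expected, of modest size, although a single prior step is a thin basis. For compound 3 the estimate is 11000 nM, within a range of 4500 nM to 30000 nM, a step of a 2.0-fold lower number from compound 2 to compound 3 (0.30 log units; within the scatter).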

Compound 3, half-maximal inhibitory concentration: 4500 nM
Beside the measured number, compound 3's estimate is 2.4-fold (0.39 log units) above it; measured number inside the range.
By their numbers in this assay, from the lowest: compound 3; then compound 2; then compound 1.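

The lengthening at this position keeps working past the first step: in this assay the chain gains one more carbon and the result is a 4.9-fold lower number from compound 2 to compound 3 (0.69 log units; beyond the scatter) on the same side as the earlier step. Read end to end, putting but-3-en-1-yl in place of vinyl gives a 14-fold lower number from compound 1 to compound 3 (1.14 log units; beyond the scatter) and turns a modest change into a large one, so across these three compounds each added chain carbon lowers the number and no compound goes against this. Nothing measured here explains why the number falls.

Going by these compounds, whether a longer chain, such as hex-5-en-1-yl, would lower the number further or reverse the trend remains open. So does the role of the end of the chain, where a saturated chain, an amine or a carboxylic acid could replace the terminal double bond.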